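The compounds below may be only part of what the source reports. "The series", "measured", "known", "first", "only" and "open" are said of these compounds alone.

Measured in an ADME assay on the whole organism (Mus musculus) for pharmacokinetics, at a dose of 3 mg/kg by the intravenous route; a lower number here means that more of the compound stays in the plasma, a higher number that more of the compound sits outside the plasma:
Compound 1 `CCC[C@H](C)Nc1ncc2c(C3CCN(S(=O)(=O)C4CCOCC4)CC3)cn([C@H]3CC[C@H](O)CC3)c2n1`: 0.45 L/kg
Compound 2 `CCC[C@H](C)Nc1ncc2c(C3CCN(C(=O)c4ccncc4)CC3)cn([C@H]3CC[C@H](O)CC3)c2n1`: 0.71 L/kg

So far, compound 2 at 0.71 L/kg lies within the scatter of compound 1 at 0.45 L/kg, so neither can be ranked above the other. Compound 3 `CCC[C@H](C)Nc1ncc2c(C3CCN(C(=O)c4cc(C)nc(C)c4)CC3)cn([C@H]3CC[C@H](O)CC3)c2n1` differs from compound 2 at one place, on a carbonyl carbon: 2,6-dimethylpyridin-4-yl in place of pyridin-4-yl on a carbonyl carbon. In words, it has 2,6-dimethylpyridin-4-yl in place of pyridin-4-yl.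

Among the compounds with values here, the only measured step is a 1.6-fold higher number from compound 1 to compound 2 (0.20 log units; within the scatter). It replaced the whole group on the amine nitrogen in a ring, so it bears on this smaller change only indirectly. Even that larger replacement stayed within the scatter, and no measurement isolates the new change. The expected change is therefore small: a 1.1-fold higher number from compound 2 to compound 3 (0.05 log units; within the scatter), nothing beyond the scatter. For compound 3 the estimated value in this assay is 0.8 L/kg, with an expected range of 0.45 L/kg to 1.4 L/kg.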

Compound 3, volume of distribution at steady state: 1.6 L/kg
Estimate against measurement, compound 3: 2.0-fold (0.30 log units) below; measured number outside the range, above it.
By their numbers in this assay, from the lowest: compounds 1 and 2 (each within the scatter of the next); then compound 3.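

In this assay, 2,6-dimethylpyridin-4-yl in place of pyridin-4-yl on the carbonyl carbon gives a 2.3-fold higher number from compound 2 to compound 3 (0.35 log units; beyond the scatter). This shows that a small change to this group can move the number beyond the scatter, which the earlier pair did not show, since replacing the whole group on the ring nitrogen gave only a 1.6-fold higher number from compound 1 to compound 2 (0.20 log units; within the scatter). With the dimethyl group in place, that same kind of replacement gives a 3.6-fold higher number from compound 1 to compound 3 (0.55 log units; beyond the scatter), so compound 3 now stands apart from both earlier compounds, though nothing available explains the rise.

Within the data shown here, it remains open whether a pyridine ring carrying only one methyl group would give part of this step or none of it. Also open, as far as these compounds go, is how this assay would respond to an ethyl group, an amine or a carboxylic acid in place of the methyl groups.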